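This account rests on a few compounds, and the source may have more. Where it says the series, first, only, none or still open, it means among the compounds named here.

Working notes on the series. For the measured compounds named here, compound 1 `C[S+]([O-])c1ccc(CSc2nc(-c3ccc(F)cc3)c(-c3ccncc3)[nH]2)cc1` is the only member with a number: in a functional assay on blood (Homo sapiens) for inhibition (a higher number here means a weaker inhibitor, a lower number a stronger inhibitor), compound 1 gives 380 nM. Compound 2 `CSc1nc(-c2ccc(F)cc2)c(-c2ccnc(NCCC(C)(C)C)c2)[nH]1` shares the core of compound 1 but carries a methylthio group and a (3,3-dimethylbutyl)amino substituent; in this assay compound 2 has "not determined" (no result reported), so there is no single number for it and nothing to place it against compound 1. Compound 3 `CCC(C)CNc1cc(-c2[nH]c(SC)nc2-c2ccc(F)cc2)ccn1` differs from compound 2 in one place: sec-butyl in place of neopentyl on a saturated chain carbon bound to a nitrogen on an aromatic ring. Going by the values given here, no measured pair in this set bridges that change, so the size of the step is an expectation only. Given that both groups leave the donor and acceptor counts unchanged, the step from compound 2 to compound 3 in this assay is expected to be none beyond the scatter. With compound 1 at 380 nM as the only anchor, compound 3 is estimated at 300 nM in this assay, with a range of 70 nM to 1300 nM.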

Compound 3, half-maximal inhibitory concentration: 2760 nM
Beside the measured number, compound 3's estimate is 9.2-fold (0.96 log units) below it; the whole stated range lies below it.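

For the compounds shown here, compound 2 carries no single number in this assay, so no step to compound 3 can be read. The compounds shown leave open what the change from 3,3-dimethylbutyl to 2-methylbutyl does to inhibition in this assay. No supporting evidence bears on this result.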